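This account rests on a few compounds, and the source may have more. Where it says the series, first, only, none or still open, it means among the compounds named here.

Measured so far:
compound 1, `CC1CCN(C2CCN(S(=O)(=O)c3cccnc3)CC2)CC1`: 2400 nM
compound 2, `CC1CCN(C2CCN(S(=O)(=O)c3cccc(N)c3)CC2)CC1`: 3400 nM

Both numbers come from a functional assay on DLD-1 cells (Homo sapiens) for antiproliferative activity, read by CellTiter-Glo, with a stated time of 72 h; on this read-out lower numbers stand for stronger inhibition and higher numbers for weaker inhibition. Compound 2 has a single neighbour on the numbers shown, and that step lies within the scatter: a 1.4-fold higher number from compound 1 to compound 2 (0.15 log units; within the scatter). An exchange of the aromatic group on the sulfonyl sulfur has thus not moved the number beyond repeat variation in this pair.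

Compound 3, `CC1CCN(C2CCN(S(=O)(=O)c3cnc(Cl)s3)CC2)CC1`, is the next member: 2-chloro-1,3-thiazol-5-yl in place of 3-aminophenyl on a sulfonyl sulfur. Within the data shown here, only one measured step bears on this change, the exchange of one aromatic group for another on the same sulfonyl sulfur, and it stayed within the scatter (a 1.4-fold higher number from compound 1 to compound 2 (0.15 log units; within the scatter)). Among the measured compounds shown here, no measured step involves a five-membered ring or a chlorine at this position, so the direction is open. On that basis no step beyond the scatter is expected in this assay, the expected step being a 1.2-fold lower number from compound 2 to compound 3 (0.08 log units; within the scatter). For compound 3 the estimate in this assay is 2800 nM, with a range from 900 nM to 8000 nM.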

Compound 3, half-maximal inhibitory concentration: 1800 nM
Beside the measured number, compound 3's estimate is 1.6-fold (0.19 log units) above it, and the stated range covers the measured number.
By their numbers in this assay, from the lowest: compounds 3, 1 and 2 (each within the scatter of the next).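

In this assay the change gives a 1.9-fold lower number from compound 2 to compound 3 (0.28 log units; within the scatter) and a 1.3-fold lower number from compound 1 to compound 3 (0.12 log units; within the scatter) on this sulfonyl sulfur, so the position now holds three aromatic groups that the numbers do not separate. The entering 2-chloro-1,3-thiazol-5-yl brings one five-membered aromatic ring with 2 hetero atoms and 0 hydrogen-bond donors in place of the six-membered aromatic ring of carbon only and 1 hydrogen-bond donor of 3-aminophenyl, and even this exchange stays within the scatter. No measurement at hand explains this result.

All compounds shown carry an aromatic group on the sulfonyl sulfur and share the remaining core, so it stays open whether a longer alkyl chain or a carboxylic acid in that place would give a step beyond the scatter. Whether the chlorine contributes anything also stays open, as no pair shown differs in that atom alone.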